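Adding One Carbon Between the Ring and the Oxygen

A few compounds are considered here, and "the series" means these few. Any claim that something is new, unique, unknown or untested is made for them only; others in the source may bear on it.

Measured compounds:
- compound 1, `CCSC(=O)C1=C(C)NC(=O)NC1c1ccco1`: 14%
- compound 2, `CC1=C(C(=O)OC2CCC2)C(c2ccco2)NC(=O)N1`: 1%

Both compounds were tested in an assay on membranes from HeLa cells for displacement of a labelled ligand from adenosine receptor A3 (Homo sapiens), read by scintillation counting, with a stated time of 180 min, tested at 1 uM; on this read-out higher numbers stand for more inhibition at the one concentration tested (going by the name of the read-out) and lower numbers for less inhibition. Within the data shown here, compound 1 gives 14%, while compound 2 gives 1%, which is the lowest of the two numbers; the single measured step, a number 13 percentage points lower from compound 1 to compound 2 (beyond the scatter), is a modest fall that lies beyond the scatter.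

Compound 3, `CC1=C(C(=O)OCC2CCC2)C(c2ccco2)NC(=O)N1`, keeps the shared core of compound 2 and changes only the group on the oxygen: cyclobutylmethyl in place of cyclobutyl on an oxygen next to a carbonyl group. Among the measured compounds shown here, no measured step concerns this kind of change; the one known step swaps a sulfur-linked group for an oxygen-linked ring and so says nothing direct about lengthening the ring-bearing chain by one carbon. With nothing pointing in either direction, no change beyond the scatter is expected in this assay, and the estimated step is a number 3 percentage points higher from compound 2 to compound 3 (within the scatter). For compound 3 the expected value is therefore 4%, with a range from -5% to 16%.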

Compound 3, a percentage reported as inhibition, at one concentration (the size of the read-out at that concentration, not a potency): 1%
Estimate against measurement, compound 3: 3 percentage points above; low and high end bracket the measured number.
By their numbers in this assay, from the lowest: compounds 2 and 3 (each within the scatter of the next); then compound 1.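

In this assay, adding one carbon to the group on the oxygen, cyclobutylmethyl in place of cyclobutyl, gives no change at the digits printed from compound 2 to compound 3 (within the scatter), so at this position the longer group does not lift the number. Replacing ethylsulfanyl on the carbonyl carbon with cyclobutylmethoxy gives a number 13 percentage points lower from compound 1 to compound 3 (beyond the scatter), which means a second oxygen-linked group now sits at the low end with compound 2, while the sulfur-linked compound 1 stays higher at 14% in these three compounds. No measurement at hand explains why these numbers fall where they do.

The swap from compound 1 to compound 3 changes the linking atom and the attached carbon group together, so the ethoxy group, which keeps the ethyl of compound 1 but links through oxygen, or cyclobutylmethylsulfanyl, which keeps the cyclobutylmethyl of compound 3 but links through sulfur, would be needed to tell these two parts apart. Also open is whether a longer chain such as cyclobutylethyl, or a chain ending in an amine, would move the number on this oxygen at all, since one added carbon is the only extension shown here.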